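Changing the side group of compound 3

The compounds below may be only part of what the source reports. "The series", "measured", "known", "first", "only" and "open" are said of these compounds alone.

Compound 1 `CC(C)CNC(=O)c1[nH]cnc1C(=O)Nc1ccc(Cl)c(Cl)c1` gives 14700 nM
Compound 2 `CCCCCCNC(=O)c1[nH]cnc1C(=O)Nc1ccc(Cl)c(Cl)c1` gives 14600 nM
Compound 3 `C[C@H](NC(=O)c1[nH]cnc1C(=O)Nc1ccc(Cl)c(Cl)c1)C(=O)OC(C)(C)C` gives 4900 nM

All three numbers come from a functional assay on HL-60 cells (Homo sapiens), with a stated time of 2 days (a lower number here means a stronger inhibitor, a higher number a weaker inhibitor), and compound 3 stands lowest, with 4900 nM as its value. Compound 4 `COC(=O)[C@@H](NC(=O)c1[nH]cnc1C(=O)Nc1ccc(Cl)c(Cl)c1)C(C)C` has not been measured yet. It differs from compound 3 in one place, on an amide-type nitrogen, with 1-(methoxycarbonyl)-2-methylpropyl in place of 1-(tert-butoxycarbonyl)ethyl (1-(methoxycarbonyl)-2-methylpropyl in place of 1-(tert-butoxycarbonyl)ethyl on an amide-type nitrogen).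

For the measured compounds named here, three measured steps bear on this change. Exchanging isobutyl for hexyl on that nitrogen gave a 1.0-fold lower number from compound 1 to compound 2 (0.00 log units; within the scatter) and so moved nothing. Putting 1-(tert-butoxycarbonyl)ethyl there gave a 3.0-fold lower number from compound 1 to compound 3 (0.48 log units; beyond the scatter) and also a 3.0-fold lower number from compound 2 to compound 3 (0.47 log units; beyond the scatter) as a second modest gain. Going by the values given here, no measured compound separates the methoxycarbonyl part from the tert-butoxycarbonyl part, so the size of this swap is not known directly.

Among the compounds with values here, the group entering compound 4 is of the same kind as the one in compound 3, so most of that modest gain should survive in this assay and any shift should be small, upward if anything. For the step itself, a 1.4-fold higher number from compound 3 to compound 4 (0.15 log units; within the scatter) is expected. Compound 4 is estimated at 7000 nM (expected range 2500 nM to 18000 nM).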

Compound 4, half-maximal inhibitory concentration: > 62500 nM
Compound 4: a limit, no number; the forecaster's own chance of this, stated with the estimate: 5%; middle value at least 8.9-fold (0.95 log units) from the limit.
By their numbers in this assay, from the lowest: compound 3; then compounds 2 and 1 (each within the scatter of the next). At a limit, above all of these: compound 4.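

In this assay, compound 4 gives no number but a limit of the assay: the limit of > 62500 nM in this assay, at which 1 of the 4 values shown sits.

Placing 1-(methoxycarbonyl)-2-methylpropyl on the amide-type nitrogen in place of 1-(tert-butoxycarbonyl)ethyl gives an at least 12-fold higher number from compound 3 to compound 4 (1.10 log units; beyond the scatter), so the modest gain seen with the tert-butyl ester does not carry over to every ester-bearing group here. Measured against the plain chains, the result is an at least 4.2-fold higher number from compound 2 to compound 4 (0.63 log units; beyond the scatter) and an at least 4.2-fold higher number from compound 1 to compound 4 (0.62 log units; beyond the scatter), which shows that a position hardly touched by the change from isobutyl to hexyl can also lose activity, and by more than the tert-butyl ester gained.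

This swap changes the ester end and the substituent on the chain carbon together, and the compounds shown cannot say which of the two carries the loss. A 1-(methoxycarbonyl)ethyl group on that nitrogen would pull the two changes apart, and a carboxylic acid in place of either ester would test whether an ester is needed at all.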